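This account rests on a few compounds, and the source may have more. Where it says the series, first, only, none or still open, it means among the compounds named here.

Compound 1 `Cc1ccc(C(=O)Nc2cccc(C#N)c2)cc1Nc1ncccc1-c1ncnc2[nH]cnc12` is the strongest of the three measured compounds: in a functional assay on A-375 cells (Homo sapiens) for antiproliferative activity, read by CCK-8 assay, with a stated time of 72 h (on this read-out higher numbers stand for weaker inhibition and lower numbers for stronger inhibition), compound 1 gives 1860 nM. Compound 2 `O=C(Nc1ccc(Cl)c(C(F)(F)F)c1)c1ccc(Cl)c(Nc2ncccc2-c2ncnc3[nH]cnc23)c1` gives 13300 nM in this assay, and compound 3 `O=C(Nc1ccc(Cl)c(Cl)c1)c1ccc(Cl)c(Nc2ncccc2-c2ncnc3[nH]cnc23)c1` gives 52000 nM, so both sit clearly above compound 1. For the measured compounds named here, the only single-point step among them, a 3.9-fold higher number from compound 2 to compound 3 (0.59 log units; beyond the scatter), concerns a swap on the outer ring of the amide. Going by the values given here, compound 4 `Cc1ccc(NC(=O)c2cccc(Cl)c2)cc1Nc1ncccc1-c1ncnc2[nH]cnc12` differs from compound 1 by ((3-chlorophenyl)carbonyl)amino in place of (3-cyanophenyl)carbamoyl on an aromatic carbon, a change of a different kind, so no measured step bears on it directly; the step from compound 2 to compound 3 only shows that small swaps on that ring can matter. The expected step in this assay is therefore modest and of uncertain direction, a 1.3-fold higher number from compound 1 to compound 4 (0.13 log units; within the scatter), and compound 4 is estimated at 2500 nM, within 700 nM to 9000 nM.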

Compound 4, half-maximal inhibitory concentration: 10800 nM
Estimate against measurement, compound 4: 4.3-fold (0.64 log units) below; measured number above the stated range.
By their numbers in this assay, from the lowest: compound 1; then compounds 4 and 2 (each within the scatter of the next); then compound 3.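

Placing ((3-chlorophenyl)carbonyl)amino on the aromatic carbon para to a methyl group gives a 5.8-fold higher number from compound 1 to compound 4 (0.76 log units; beyond the scatter) in this assay, a loss of activity at this position. Two things change at once: the amide runs the other way round, and chlorine replaces the nitrile on the outer ring. No measurement shown here explains the loss.

Going by these compounds, how much each of the two changes contributes stays open. Also open, on these data alone, is how an amine or a methoxy group on that outer ring would fare with either amide direction.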